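The source may hold more compounds than are shown below. What is called first, only, known or untested is meant among the compounds shown, and "the series" means these compounds.

Working notes on the series. Going by the values given here, compound 2 `NS(=O)(=O)c1cc(-c2nnc(CNC(=O)c3ccccc3)o2)c(Cl)cc1SCc1ccccc1` is the analogue of compound 1 `CC(C)(O)c1cn(Cc2nnc(-c3cc(S(N)(=O)=O)c(SCc4ccccc4)cc3Cl)o2)nn1` in which the step of a 1.5-fold higher number from compound 1 to compound 2 (0.19 log units; within the scatter) was the only change. In a functional assay on HeLa cells (Homo sapiens) for cytotoxicity, read by MTT assay, with a stated time of 72 h (a lower number here means a stronger inhibitor, a higher number a weaker inhibitor), compound 1 gives 68000 nM and compound 2 gives 105000 nM, so compound 2 holds the higher of the two numbers measured, but the gap to compound 1 stays inside the scatter and gives no order between them.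

Compound 3 `NS(=O)(=O)c1cc(-c2nnc(/C=C/c3cccc(Cl)c3)o2)c(Cl)cc1SCc1ccccc1` differs from compound 2 by 2-(3-chlorophenyl)ethenyl in place of benzamidomethyl on an aromatic carbon. Among the compounds with values here, the only measured step, the one from compound 1 to compound 2, touched a different position of the shared core and was itself within the scatter; no step that exchanges the group on this carbon of the five-membered ring has been measured. Within the data shown here, nothing in the numbers so far points to a large shift in either direction, so compound 3 is expected near compound 2, with the step of a 1.3-fold lower number from compound 2 to compound 3 (0.12 log units; within the scatter) estimated to fall within the scatter. For compound 3 the estimate in this assay is 80000 nM, with a range from 25000 nM to 250000 nM.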

Compound 3, half-maximal inhibitory concentration: 16000 nM
The estimate for compound 3 lay 5.0-fold (0.70 log units) above the measured number; the measured number lies below the stated range.
By their numbers in this assay, from the lowest: compound 3; then compounds 1 and 2 (each within the scatter of the next).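

The carbon of the five-membered ring next to the ring nitrogen and the ring oxygen is where a change first moves the number in this assay beyond the scatter: 2-(3-chlorophenyl)ethenyl in place of benzamidomethyl gives a 6.6-fold lower number from compound 2 to compound 3 (0.82 log units; beyond the scatter). The same group in place of (4-(1-hydroxy-1-methylethyl)-1H-1,2,3-triazol-1-yl)methyl gives a 4.3-fold lower number from compound 1 to compound 3 (0.63 log units; beyond the scatter), so the lower number holds against both other groups at this carbon. Nothing at hand accounts for the shift.

Going by these compounds, the step exchanges the link to the phenyl ring and adds the chlorine at once, so the share of each in the shift stays open. Also open, on these data alone, is whether 2-phenylethenyl without chlorine, a saturated 2-(3-chlorophenyl)ethyl chain or an amine at this carbon would keep the number near that of compound 3.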